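Ethyl for Cyclobutyl: Expected Change in Hepatocyte Clearance

This account rests on a few compounds, and the source may have more. Where it says the series, first, only, none or still open, it means among the compounds named here.

Compound 1 `CN(C)C(=O)CN1CCC(c2cc3c(-c4ccc(=O)n(C5CCC5)c4)ccnc3[nH]2)CC1`: 5.8 uL/min
Compound 2 `CC(C)n1cc(-c2ccnc3[nH]c(C4CCN(CC(=O)N5CCCCC5)CC4)cc23)ccc1=O`: 26 uL/min

Of the compounds shown here, two have been measured in an ADME assay on cells (Hepatocyte, Rattus norvegicus) for metabolic stability; a higher number here means faster removal of the compound, a lower number slower removal. Compound 1 gives 5.8 uL/min, and compound 2 gives 26 uL/min. Compound 1 therefore stands as the lower of the two numbers, and the gap to compound 2 is beyond the usual scatter of this assay. For the measured compounds named here, compound 2 differs from compound 1 in more than one place, so the two values show only that compound 1 is removed more slowly; no single cause can be read from them.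

Going by the values given here, the next compound, compound 3 `CCn1cc(-c2ccnc3[nH]c(C4CCN(CC(=O)N(C)C)CC4)cc23)ccc1=O`, keeps the shared core and the dimethylamide of compound 1 and changes only one group: ethyl in place of cyclobutyl on an aromatic nitrogen. Among the compounds with values here, no measured pair isolates this change, so its effect is unknown. Since compound 1 stands at the slower end of what has been seen, compound 3 is expected to stay close to it, with a step of a 1.3-fold lower number from compound 1 to compound 3 (0.11 log units; within the scatter) that lies within the scatter or only slightly below. The estimate for compound 3 in this assay is 4.5 uL/min, ranging from 2 uL/min to 11 uL/min.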

Compound 3, intrinsic clearance in a liver preparation (reported as CLH), per the amount of preparation that the assay uses in the Hepatocyte assay: < 1 uL/min
Compound 3: only a limit was reported; the forecaster's own chance of this, stated with the estimate: 10%; middle value at least 4.5-fold (0.65 log units) from the limit.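

Putting ethyl in place of cyclobutyl on the aromatic nitrogen gives, in the Hepatocyte assay, an at least 5.8-fold lower number from compound 1 to compound 3 (0.76 log units; beyond the scatter), so a change at this one position is enough to slow removal beyond the scatter, something the earlier pair, which differs in more than one place, could not show. In a physicochemical assay for lipophilicity, using the shake flask method, measured as octanol-water partition, at pH 7.4 (on this read-out higher numbers stand for higher lipophilicity and lower numbers for lower lipophilicity), compound 1 gives 1.9 and compound 3 gives 1.2, and the slower removal of compound 3 may follow from its lower lipophilicity, although a single pair can only suggest this: the measured distribution coefficient of compound 1, 1.9, and of compound 3, 1.2, a number 0.70 log units lower (beyond the scatter)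

The figure for compound 3 in the Hepatocyte assay is a limit of the assay and not a number, so the step gives only a minimum size and the true gap may be larger: the limit of < 1 uL/min in the Hepatocyte assay, at which 1 of the 3 values shown sits.

Compound 1 and compound 3 differ in the loss of the ring and in lipophilicity at once, so this pair cannot tell which of the two matters for removal. A cyclopropyl or a methyl group on the same nitrogen, with the rest of compound 3 kept, would help to separate ring from chain and show how far the trend runs.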